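Replacing the 4-methoxyphenyl on the sugar-bearing core

This account rests on a few compounds, and the source may have more. Where it says the series, first, only, none or still open, it means among the compounds named here.

The series shares one core; compound 1 `CCn1c(=O)n(C2OC(CO)[C@@H](O)[C@H]2O)c2nc(N)nc(O)c21` carries a methyl on the saturated chain carbon bound to an aromatic nitrogen and gives 15 uM in a functional assay (B cells) with Mus musculus as the target; a lower number here means that less compound is needed, a higher number that more compound is needed for the effect. Compound 2 `C=CCn1c(=O)n(Cc2ccccc2)c2nc(N)nc(O)c21` lacks the sugar and gives 5 uM. Compound 3 `COc1ccc(Cn2c(=O)n(C3OC(CO)[C@@H](O)[C@H]3O)c3nc(N)nc(O)c32)cc1` gives 135 uM, the highest of the three numbers: it sits a 9.0-fold higher number from compound 1 to compound 3 (0.95 log units; beyond the scatter), and its number is also higher than that of compound 2.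

The next compound, compound 4 `CN(C)CCCn1c(=O)n(C2OC(CO)[C@@H](O)[C@H]2O)c2nc(N)nc(O)c21`, differs from compound 3 in one place: 2-(dimethylamino)ethyl in place of 4-methoxyphenyl on a saturated chain carbon bound to an aromatic nitrogen.

Among the measured compounds shown here, only one measured step bears on this change, the one that shows the 4-methoxyphenyl entering in place of methyl, a 9.0-fold higher number from compound 1 to compound 3 (0.95 log units; beyond the scatter). Compound 4 removes that 4-methoxyphenyl again, though what enters is the 2-(dimethylamino)ethyl rather than the methyl of compound 1, so the return need not be complete. For the measured compounds named here, compound 2 gives no step to compound 3 and does not constrain the direction further.

The expectation is therefore a lower number in this assay, a 6.8-fold lower number from compound 3 to compound 4 (0.83 log units; beyond the scatter), carrying compound 4 back toward compound 1 because of a 9.0-fold higher number from compound 1 to compound 3 (0.95 log units; beyond the scatter). Compound 4 is estimated at 20 uM, with a range from 6 uM to 70 uM.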

Compound 4, concentration for half-maximal effect: 194 uM
Beside the measured number, compound 4's estimate is 9.7-fold (0.99 log units) below it; the measured number lies above the stated range.
By their numbers in this assay, from the lowest: compound 2; then compound 1; then compounds 3 and 4 (each within the scatter of the next).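

In this assay, replacing the 4-methoxyphenyl with the 2-(dimethylamino)ethyl gives a 1.4-fold higher number from compound 3 to compound 4 (0.16 log units; within the scatter), so this position does not separate these two groups, and a six-membered aromatic ring is not required for a number in this range. The comparison with the methyl-bearing parent gives a 13-fold higher number from compound 1 to compound 4 (1.11 log units; beyond the scatter), which lies beyond the scatter and has the same direction as a 9.0-fold higher number from compound 1 to compound 3 (0.95 log units; beyond the scatter); among these three sugar-bearing compounds, both the 4-methoxybenzyl and the 3-(dimethylamino)propyl carry higher numbers than the substituent of compound 1, and none of the three goes against this. No supporting data explain why these two different groups fall within the scatter of each other.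

On these data alone, it remains open whether the higher number follows from extending the chain alone or depends on what the chain carries, a question that a plain propyl or butyl chain on the same core would address. A carboxylic acid at the end of the chain, or a primary amine in place of the dimethylamino group, would show whether the end group matters at this position at all.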